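This account rests on a few compounds, and the source may have more. Where it says the series, first, only, none or still open, it means among the compounds named here.

Working notes on the series. Compound 1 `Cc1ccccc1-c1ccc(CCC(=O)N2CCCC2)cc1` is measured in an assay on HEK293 cells for inhibition of N-acylethanolamine-hydrolyzing acid amidase (Rattus norvegicus), read by LC-MS, with a stated time of 30 min; on this read-out lower numbers stand for stronger inhibition and higher numbers for weaker inhibition. In this assay compound 1 returns only a limit, > 100000 nM. The other measured compound, compound 2 `O=C(O)c1cccc(CCCCCCC(=O)N2CCCC2)c1`, likewise returns only a limit in this assay, > 100000 nM. For the measured compounds named here, compound 1 therefore cannot be placed on a scale of numbers: both values shown sit at the limit of > 100000 nM in this assay, at which 2 of the 2 values shown sit, and no measured step between compounds exists from which a direction could be read. The compound awaiting measurement is compound 3 `O=C(CCc1ccc(-c2cccs2)cc1)N1CCCC1`, which differs from compound 1 by thiophen-2-yl in place of 2-methylphenyl on an aromatic carbon. With both measured values resting at the same limit there is no measured change on which to anchor a direction for this change, so the step expected in this assay is a number no higher from compound 1 to compound 3 (the limit leaves the size open), and the most likely outcome is that this assay again reports only a limit rather than a number. On that basis compound 3 is estimated in this assay at 100000 nM, with a range from 20000 nM to 300000 nM.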

Compound 3, half-maximal inhibitory concentration: > 100000 nM
Compound 3 ended at the assay's limit; the forecaster's own chance of this, stated with the estimate: 70%; the middle value sits exactly at the limit.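

The step from compound 1 to compound 3 cannot be read in this assay, as both compounds return only a limit: the limit of > 100000 nM in this assay, at which 3 of the 3 values shown sit.

The compounds shown leave open whether thiophen-2-yl and 2-methylphenyl differ at all in their effect on inhibition, and what any of the three compounds would give as a number rather than a limit in this assay.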